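The source may report more compounds than this note shows. Statements on the series, on what has been measured and on what is new or still open speak of the compounds shown alone.

Series notes, receptor binding

Three compounds of this set have been run in an assay on membranes from brain for displacement of a labelled ligand from Sigma non-opioid intracellular receptor 1 (Cavia porcellus), read by scintillation counting, with a stated time of 120 min; on this read-out higher numbers stand for weaker inhibition and lower numbers for stronger inhibition. Compound 1 `O=[N+]([O-])c1ccc(-c2scc3c2CCOC32CCN(Cc3ccccc3)CC2)cc1` gives 1.7 nM in this assay. Compound 2 `COC1Cc2c(csc2-c2ccc([N+](=O)[O-])cc2)C2(CCN(Cc3ccccc3)CC2)O1` carries methoxy in place of hydrogen on a saturated ring carbon relative to compound 1; in this assay compound 2 gives 1 nM. The step of a 1.7-fold lower number from compound 1 to compound 2 (0.23 log units; within the scatter) is recorded as within the usual scatter, so the two numbers are not told apart here. Compound 3 `c1ccc(CN2CCC3(CC2)OCCc2c(-c4ccccc4)csc23)cc1` rests on a different core; how the core of compound 3 differs from that of compound 1 is not broken down here. In this assay compound 3 gives 1.6 nM. Set against the other two, the number for compound 3 sits within the scatter of both compound 1 and compound 2, so no order among the three measured compounds can be claimed.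

Compound 4 `COC1Cc2c(-c3ccccc3)csc2C2(CCN(Cc3ccccc3)CC2)O1` has not yet been measured. It differs from compound 3 by methoxy in place of hydrogen on a saturated ring carbon. The change is the same as the one between compound 1 and compound 2, made at the same place on the ring, and it occurs twice among the compounds shown. Because that earlier step a 1.7-fold lower number from compound 1 to compound 2 (0.23 log units; within the scatter) stayed within the scatter, a step of about the same size is expected here, a 1.5-fold lower number from compound 3 to compound 4 (0.16 log units; within the scatter), with the value for compound 4 resting on the number for compound 3 1.6 nM as its anchor. Compound 4 is therefore estimated at 1.1 nM in this assay, with a likely range from 0.5 nM to 2.5 nM.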

Compound 4, inhibition constant: 5.4 nM
Compound 4: middle estimate off by 4.9-fold (0.69 log units), on the low side, and the stated range ends below it.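

In this assay, methoxy in place of hydrogen on a saturated ring carbon gives a 3.4-fold higher number from compound 3 to compound 4 (0.53 log units; beyond the scatter), and set beside the earlier step on the other core, the same change does not read the same on the two cores: the same change on two cores in this assay, a 1.7-fold lower number (0.23 log units; within the scatter) from compound 1 to compound 2 and a 3.4-fold higher number (0.53 log units; beyond the scatter) from compound 3 to compound 4, 5.7-fold (0.76 log units) apart, beyond the scatter of two such steps For this series, a step read on one core is therefore not a safe basis for predicting the same change on the other, since the change cannot be told from no change on the core of compound 1 but weakens inhibition modestly on the core of compound 3. Among the compounds shown here, this rests on only two matched pairs and does not show why the cores part, which feature of the cores is responsible, or whether the difference would hold on any further core.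

Which of the differences between the core of compound 1 and the core of compound 3 goes with the gap remains open, as the compounds shown offer no pair that separates them. Also open, as far as these compounds go, is whether a hydroxyl group or a longer chain such as ethoxy on the same saturated ring carbon would show the same dependence on the core as methoxy.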